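The compounds below may be only part of what the source reports. "The series", "measured", "known", "first", "only" and "open" are said of these compounds alone.

Measured in an assay on HEK293 cells for inhibition of N-acylethanolamine-hydrolyzing acid amidase (Rattus norvegicus), read by LC-MS, with a stated time of 30 min; a lower number here means a stronger inhibitor, a higher number a weaker inhibitor:

- compound 1, `O=C(CCCCCCc1ccccc1)N1CCCC1`, gives 12900 nM
- compound 2, `O=C(CCCCCCc1ccccc1F)N1CCCC1`, gives 13700 nM
- compound 3, `O=C(CCCCCCc1cccc(Cl)c1)N1CCCC1`, gives 3700 nM

Among these three numbers, compound 1 stands second highest. Compound 2 lies within the scatter of it, so the two cannot be told apart, while compound 3 is the furthest away, with a lower number. The two single changes measured so far both replace a hydrogen on the aromatic ring with a halogen: a 1.1-fold higher number from compound 1 to compound 2 (0.03 log units; within the scatter), and a 3.5-fold lower number from compound 1 to compound 3 (0.54 log units; beyond the scatter).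

Compound 4, `O=C(CCCCCCc1cccnc1)N1CCCC1`, alters compound 1 in a different way: pyridin-3-yl in place of phenyl on a saturated chain carbon, six bonds along the chain from a carbonyl carbon. Here one atom inside the ring is exchanged rather than a group attached to it, and no measured step covers such an exchange. The two halogen steps show that small additions to the ring leave the number either unchanged or modestly lower, but they say nothing about how a ring nitrogen, which brings the one hydrogen-bond acceptor, will be read in this assay. Among the measured compounds shown here, with no comparable step to lean on, the expectation is no change beyond the scatter, with a wide range to either side. Compound 4 is therefore estimated at 15000 nM, between 5000 nM and 45000 nM. This estimate corresponds to an expected 1.2-fold higher number from compound 1 to compound 4 (0.07 log units; within the scatter).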

Compound 4, half-maximal inhibitory concentration: > 100000 nM
Compound 4 ended at the assay's limit; the forecaster's own chance of this, stated with the estimate: 10%; middle value at least 6.6-fold (0.82 log units) from the limit.
By their numbers in this assay, from the lowest: compound 3; then compounds 1 and 2 (each within the scatter of the next). At a limit, above all of these: compound 4.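

Pyridin-3-yl in place of phenyl gives an at least 7.7-fold higher number from compound 1 to compound 4 (0.88 log units; beyond the scatter) in this assay, which runs opposite to the chloro step, a 3.5-fold lower number from compound 1 to compound 3 (0.54 log units; beyond the scatter). The earlier compounds shown here changed only what is attached to the aromatic ring, and their steps left the number unchanged or modestly lower; this step shows that exchanging an atom inside the ring, with the same number of heavy atoms and a hydrogen-bond acceptor entering, can raise the number beyond the scatter. The value of compound 4, > 100000 nM, is a limit of the assay and not a number, so only the direction of the step and its smallest possible size can be read: the limit of > 100000 nM in this assay, at which 1 of the 4 values shown sits.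

As far as these compounds go, how far beyond that limit compound 4 lies remains unknown, as does whether a ring nitrogen at another place in the ring would give a similar result. From the compounds shown here alone, it also remains open whether a cyclohexyl ring in place of phenyl, or an amine or a carboxylic acid on the phenyl ring, would raise the number as well or leave it close to that of compound 1.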